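The compounds below may be only part of what the source reports. "The series", "measured", "known", "first", "only" and "open" are said of these compounds alone.

Of the compounds shown here, three have values so far in an ADME assay on microsomes from liver (Homo sapiens) for metabolic stability, using NADPH, with a stated time of 40 min, tested at 2 uM; a lower number here means that the compound disappears faster, a higher number that the compound lasts longer. Compound 1 (`Cc1cccc2c(-c3ccc4c(O)cccc4n3)c[nH]c12`) gives 0.283 h, compound 2 (`Cc1cccc2c(-c3ccc4cccc(Br)c4n3)c[nH]c12`) gives 2.4 h and compound 3 (`Clc1cccc2c(-c3ccc4ccccc4n3)c[nH]c12`) gives 0.283 h. Compound 3 therefore stands level with compound 1, and both lie well under compound 2, a gap beyond the scatter.

The next step leads to compound 4 (`Cc1cccc2c(-c3ccc4ccccc4n3)c[nH]c12`), with methyl in place of chloro on an aromatic carbon. The data hold no measured case of this swap alone. Compound 1 and compound 2 both carry the methyl, yet their half-lives stand far apart, and each also has a further group that compound 4 lacks. They give little guidance on the swap, and the expectation rests mainly on compound 3 at 0.283 h. A slight rise, none beyond the scatter in this assay, is expected, with the estimated step being a 1.4-fold higher number from compound 3 to compound 4 (0.15 log units; within the scatter). For compound 4 the estimated half-life is 0.4 h, with an expected range from 0.2 h to 1 h.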

Compound 4, half-life: 0.35 h
The estimate for compound 4 lay 1.1-fold (0.06 log units) above the measured number; low and high end bracket the measured number.
By their numbers in this assay, from the lowest: compounds 1, 3 and 4 (each within the scatter of the next); then compound 2.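

In this assay, the swap of chloro for methyl now has a measured case, a 1.2-fold higher number from compound 3 to compound 4 (0.09 log units; within the scatter), so the two groups are not separated on this aromatic carbon of the core. Hydrogen in place of hydroxy gives a 1.2-fold higher number from compound 1 to compound 4 (0.09 log units; within the scatter), again with no separation. Bromo is the one group here that separates: a 6.9-fold lower number from compound 2 to compound 4 (0.84 log units; beyond the scatter) is the only one of these steps beyond the scatter, and methyl alone does not carry the longer half-life.

Nothing shown accounts for the size of the bromo step. Going by these compounds, it also remains open whether fluoro, methoxy or an amine on the carbon that holds bromo in compound 2 would give a similarly long half-life.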